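The source may hold more compounds than are shown below. What is called first, only, known or untested is meant among the compounds shown, and "the series" means these compounds.

Measured so far in a functional assay on MDA-MB-231 cells (Homo sapiens) for antiproliferative activity, read by MTT assay, with a stated time of 72 h; a lower number here means a stronger inhibitor, a higher number a weaker inhibitor:

compound 1 `COc1cc(-c2nccn2CC(C)C)cc(OC)c1OC`: > 100000 nM (a limit)
compound 2 `COc1cccc(-n2ccnc2-c2cc(OC)c(OC)c(OC)c2)c1`: 18300 nM

The reading for compound 1 is a limit and not a number. Compound 1 thus marks (the limit of > 100000 nM in this assay, at which 1 of the 2 values shown sits). Within the data shown here, compound 2 at 18300 nM holds the only actual number so far, with nothing yet to rank it against. Among the measured compounds shown here, the one measured step is an at least 5.4-fold lower number from compound 1 to compound 2 (0.73 log units; beyond the scatter), with 3-methoxyphenyl in place of isobutyl on an aromatic nitrogen.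

Compound 3 `COc1cc(-c2nccn2-c2ccc(Br)cc2)cc(OC)c1OC` has not been measured. It carries 4-bromophenyl in place of 3-methoxyphenyl on the same aromatic nitrogen: 4-bromophenyl in place of 3-methoxyphenyl on an aromatic nitrogen.

The measured step bears on this only loosely. It brought a six-membered aromatic ring of carbon only onto that nitrogen, and compound 3 keeps such a ring. For the measured compounds named here, no measured step exchanges one such ring for another. No shift beyond the scatter is therefore expected in this assay, and neither direction can be favoured. The expected change is a 1.1-fold lower number from compound 2 to compound 3 (0.06 log units; within the scatter). Compound 3 is estimated at 16000 nM. The expected range for compound 3 runs from 4000 nM to 60000 nM.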

Compound 3, half-maximal inhibitory concentration: 8400 nM
Compound 3: the middle estimate sits 1.9-fold (0.28 log units) above what was measured; the range from low to high includes it.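

Among these compounds, exchanging one six-membered aromatic ring of carbon only for another on this aromatic nitrogen is not neutral in this assay: 4-bromophenyl in place of 3-methoxyphenyl gives a 2.2-fold lower number from compound 2 to compound 3 (0.34 log units; beyond the scatter), and the earlier compounds held no such exchange. Against isobutyl, the same 4-bromophenyl group gives an at least 11-fold lower number from compound 1 to compound 3 (1.07 log units; beyond the scatter), so at this position the choice of ring substituent matters as well as the presence of the ring. That larger step is a bound and not a plain ratio, as the reading for compound 1 is a limit: the limit of > 100000 nM in this assay, at which 1 of the 3 values shown sits.

Compound 2 and compound 3 differ both in the substituent and in where it sits on the ring, so the series cannot yet separate bromine from methoxy or the effect of substituent identity from that of its placement; 3-bromophenyl and 4-methoxyphenyl would settle this. Also open, on these data alone, is how the same nitrogen would read with an amine or a carboxylic acid on the ring, or with an unsubstituted phenyl group.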